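Trading Oxolane for Cyclopentene on the Chlorophenyl Ring

The compounds below may be only part of what the source reports. "The series", "measured", "known", "first", "only" and "open" are said of these compounds alone.

Compound 3 `Cn1nc2c(=O)n(CC3(O)CCN(Cc4ccc(C5CCCO5)cc4Cl)CC3)cnc2c1-c1ccc(CN)cc1` stands at the top of the three measured numbers in an assay on isolated protein for inhibition of ubiquitin carboxyl-terminal hydrolase 7 (Homo sapiens), with stated times of 30 min and 2 h (on this read-out higher numbers stand for weaker inhibition and lower numbers for stronger inhibition), where compound 3 gives 3820 nM. By comparison, compound 1 `Cn1nc2c(=O)n(CC3(O)CCN(Cc4ccc(-c5ccncc5)cc4Cl)CC3)cnc2c1-c1ccc(CN)cc1` gives 257 nM, and compound 2 `Cn1nc2c(=O)n(CC3(O)CCN(Cc4ccc(-n5ccnc5)cc4Cl)CC3)cnc2c1-c1ccc(CN)cc1` gives 228 nM. Both measured steps that touch this position were large: a 15-fold higher number from compound 1 to compound 3 (1.17 log units; beyond the scatter) and a 17-fold higher number from compound 2 to compound 3 (1.22 log units; beyond the scatter). Compound 4 `Cn1nc2c(=O)n(CC3(O)CCN(Cc4ccc(C5=CCCC5)cc4Cl)CC3)cnc2c1-c1ccc(CN)cc1` carries cyclopent-1-en-1-yl in place of oxolan-2-yl on an aromatic carbon. Going by the values given here, no measured pair shows an aromatic-to-carbocyclic change of this kind, so the expectation for compound 4 rests on the observation that the two aromatic groups of compound 1 and compound 2 gave far lower numbers than the oxolane of compound 3. Compound 4 is therefore expected to reach 1500 nM, within a range from 400 nM to 6000 nM. This estimate corresponds to an expected 2.5-fold lower number from compound 3 to compound 4 (0.41 log units; beyond the scatter).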

Compound 4, half-maximal inhibitory concentration: 76.9 nM
Beside the measured number, compound 4's estimate is 20-fold (1.29 log units) above it, outside the stated range (below it).
By their numbers in this assay, from the lowest: compound 4; then compounds 2 and 1 (each within the scatter of the next); then compound 3.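

In this assay the carbon-only cyclopent-1-en-1-yl, with the same heavy-atom count as oxolan-2-yl, gives a 50-fold lower number from compound 3 to compound 4 (1.70 log units; beyond the scatter) at this position on the aromatic ring. It also goes beyond both aromatic groups, with a 3.0-fold lower number from compound 2 to compound 4 (0.47 log units; beyond the scatter) and a 3.3-fold lower number from compound 1 to compound 4 (0.52 log units; beyond the scatter) among the steps, so an aromatic group here is not needed for the lowest number of the four compounds. Nothing shown accounts for these steps. On these data alone, whether a saturated cyclopentyl ring, an open pentyl chain or an amine such as pyrrolidin-1-yl would match compound 4 at this position remains open.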